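From Propylamide to Butyl Ester on the Shared Core

The compounds below may be only part of what the source reports. "The series", "measured", "known", "first", "only" and "open" are said of these compounds alone.

Of the compounds shown here, three built on one shared core have been tested in a functional assay on SK-BR-3 cells (Homo sapiens) for antiproliferative activity, read by MTT assay, with a stated time of 72 h; on this read-out higher numbers stand for weaker inhibition and lower numbers for stronger inhibition. Compound 1 `C/C=C1/[C@H](O[C@@H]2O[C@H](CO)[C@@H](O)[C@H](O)[C@H]2O)OC=C(C(=O)OC)[C@H]1CC(=O)NCCC` carries a (propylcarbamoyl)methyl group. In this assay compound 1 gives > 20000 nM, which is a limit of the assay and not a number. Compound 2 `C#CCOC(=O)C[C@@H]1C(C(=O)OC)=CO[C@@H](O[C@@H]2O[C@H](COC(C)=O)[C@@H](OC(C)=O)[C@H](OC(C)=O)[C@H]2OC(C)=O)/C1=C/C` also gives only a limit in this assay, > 15000 nM. Compound 3 `C/C=C1/[C@H](O[C@@H]2O[C@H](CO)[C@@H](O)[C@H](O)[C@H]2O)OC=C(C(=O)OC)[C@H]1CC(=O)OCCc1ccc([N+](=O)[O-])cc1` gives > 20000 nM in this assay, again a limit. So compound 1 stands nowhere distinct: all three values shown are limits, two of them at the limit of > 20000 nM in this assay, at which 2 of the 3 values shown sit, and one at the limit of > 15000 nM in this assay, at which 1 of the 3 values shown sits. Among the compounds with values here, the only single-point change among the measured compounds, from compound 1 to compound 3, is a step that the two limits leave unreadable from compound 1 to compound 3, since both ends are limits.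

Compound 4 `C/C=C1/[C@H](O[C@@H]2O[C@H](CO)[C@@H](O)[C@H](O)[C@H]2O)OC=C(C(=O)OC)[C@H]1CC(=O)OCCCC` differs from compound 1 in one place: butoxy in place of propylamino on a carbonyl carbon. Within the data shown here, no measured step reads this particular change, and the one measured step is unreadable. With every measured relative showing only a limit, no movement beyond the scatter is expected in this assay; the step from compound 1 to compound 4 is estimated as a step that the limit leaves unreadable from compound 1 to compound 4. For compound 4 the estimate in this assay is 30000 nM, with an expected range from 8000 nM to 100000 nM.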

Compound 4, half-maximal inhibitory concentration: > 15000 nM
Compound 4 gave a limit, no number; the forecaster's own chance of this, stated with the estimate: 85%; the middle value is on the limit's open side.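

Compound 4 gives > 15000 nM, a limit of the assay and not a number. Its steps from compound 1 and from compound 3 cannot be read, with limits at both ends of each. The compounds shown leave open whether butoxy in place of propylamino on a carbonyl carbon changes antiproliferative activity at all.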